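Trifluoromethoxy for Methoxy on the Aryl Amide

The source may hold more compounds than are shown below. What is called first, only, known or untested is meant among the compounds shown, and "the series" means these compounds.

Going by the values given here, compound 3 `COc1ccc(C(=O)Nc2c(C(O)(C(F)(F)F)C(F)(F)F)ccc3ccccc23)cc1` gives 417 nM in an assay on LtK cells with ATP-sensitive inward rectifier potassium channel 11 (Homo sapiens) as the target (on this read-out higher numbers stand for an effect only at larger amounts of compound and lower numbers for an effect already at smaller amounts), the highest of the three numbers measured so far. Compound 1 `O=C(Nc1c(C(O)(C(F)(F)F)C(F)(F)F)ccc2ccccc12)C1CCC1` gives 45 nM in this assay, and compound 2 `Cc1cccc(C(=O)Nc2c(C(O)(C(F)(F)F)C(F)(F)F)ccc3ccccc23)c1` gives 23 nM in this assay. Both steps that lead to compound 3 go upward: a 9.3-fold higher number from compound 1 to compound 3 (0.97 log units; beyond the scatter), and an 18-fold higher number from compound 2 to compound 3 (1.26 log units; beyond the scatter). The pair of compounds 1 and 2 shows a 2.0-fold lower number from compound 1 to compound 2 (0.29 log units; within the scatter).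

Compound 4 `O=C(Nc1c(C(O)(C(F)(F)F)C(F)(F)F)ccc2ccccc12)c1ccc(OC(F)(F)F)cc1` differs from compound 3 by trifluoromethyl in place of methyl on an oxygen on an aromatic ring. Among the compounds with values here, none of the measured steps touches this position; the earlier steps exchange the whole group on the carbonyl carbon, and they establish only that the 4-methoxyphenyl of compound 3 is the weakest of the three on this assay. Whether a trifluoromethyl on that oxygen recovers any of the ground lost from compound 1 or compound 2 cannot be read from these data.

The expectation for compound 4 on this assay is therefore a step of a 1.7-fold lower number from compound 3 to compound 4 (0.22 log units; within the scatter), close to no change beyond the scatter, with wide uncertainty in both directions. Compound 4 is estimated at 250 nM, with a range from 60 nM to 1000 nM.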

Compound 4, half-maximal effective concentration: > 10000 nM
Compound 4 was reported as a limit (the forecaster's own chance of this, stated with the estimate: 5%); middle value at least 40-fold (1.60 log units) away from the limit.
By their numbers in this assay, from the lowest: compounds 2 and 1 (each within the scatter of the next); then compound 3. At a limit, above all of these: compound 4.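

Compound 4 is reported in this assay only as a limit and not as a number: the limit of > 10000 nM in this assay, at which 1 of the 4 values shown sits. The earlier steps shown here exchanged the whole group on the carbonyl carbon, so they left the substituent on this oxygen untested; here a single change on the oxygen gives an at least 23-fold higher number from compound 3 to compound 4 (1.37 log units; beyond the scatter) and shows that the position is far from silent. Measured against the other two groups on the carbonyl carbon, 4-(trifluoromethoxy)phenyl gives an at least 430-fold higher number from compound 2 to compound 4 (2.63 log units; beyond the scatter) and an at least 220-fold higher number from compound 1 to compound 4 (2.34 log units; beyond the scatter) and places compound 4 above all three earlier compounds, so the spread among compounds 1, 2 and 3 did not mark how far this read-out can move within the series.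

Going by these compounds, the true size of all three steps stays unknown, since each rests on a limit, and nothing here separates the trifluoromethyl itself from other replacements, such as an ethyl or longer chain on the oxygen or an amine in place of the methoxy. On these data alone, whether trifluoromethoxy would cost as much on the 3-methylphenyl of compound 2 also remains open.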